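The source may hold more compounds than are shown below. What is called first, only, known or untested is meant among the compounds shown, and "the series" means these compounds.

Measured so far in an in vitro ADME assay on microsomes from liver (Rattus norvegicus) for metabolic stability; on this read-out higher numbers stand for fast clearance and lower numbers for slow clearance:
- compound 1 `CNC[C@]1(O)Cc2ccccc2[C@@H]1Oc1ccccc1CO`: "not determined" (no result reported)
- compound 2 `CNC[C@]1(O)Cc2ccccc2[C@@H]1Oc1c(C)cccc1F`: 17 mL/min/kg

Within the data shown here, compound 2, at 17 mL/min/kg, holds the only number, so it cannot be placed high or low against any other compound. Compound 1 offers no number for comparison.

The next compound is compound 3 `CNC[C@]1(O)Cc2ccccc2[C@@H]1Oc1ccccc1F`. Its difference from compound 2 is hydrogen in place of methyl on an aromatic carbon, ortho to a large group and meta to a fluoro group. Among the measured compounds shown here, no measured pair shows what such a change does in this assay, so neither its size nor its direction has support from data. The expected step of a 1.1-fold lower number from compound 2 to compound 3 (0.05 log units; within the scatter) stays within the usual scatter of repeated measurements. For compound 3, the estimated clearance is 15 mL/min/kg, with an expected range of 7 mL/min/kg to 30 mL/min/kg.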

Compound 3, clearance: <= 3 mL/min/kg
Compound 3 gave a limit, no number; the forecaster's own chance of this, stated with the estimate: 5%; at least 5.0-fold (0.69 log units) between middle value and limit.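

In this assay, hydrogen in place of methyl on an aromatic carbon, ortho to a large group and meta to a fluoro group, gives an at least 5.6-fold lower number from compound 2 to compound 3 (0.75 log units; beyond the scatter). Among these compounds, this is the first pair to be read at this position, and it shows that the change moves the read-out beyond the usual scatter, towards slower clearance. Compound 3 gives a limit of the assay and not a number, so the step has a lower bound only: the limit of <= 3 mL/min/kg in this assay, at which 1 of the 3 values shown sits.

Going by these compounds, whether a chloro or a methoxy group on this aromatic carbon would read closer to compound 2 or to compound 3 stays open. Also open, on these data alone, is whether the step would hold with a nitrile in place of the fluoro group.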